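A few compounds are considered here, and "the series" means these few. Any claim that something is new, unique, unknown or untested is made for them only; others in the source may bear on it.

In a functional assay on Jurkat cells (Homo sapiens) for inhibition (a lower number here means a stronger inhibitor, a higher number a weaker inhibitor), compound 1 `COC(=O)c1cc(OCC(=O)[C@H](CC(=O)O)NC(=O)[C@@H](NC(=O)COc2cccc3ccccc23)C(C)C)no1` gives 71000 nM. Compound 2 `CC(C)[C@H](NC(=O)COc1cccc2ccccc12)C(=O)N[C@@H](CC(=O)O)C(=O)CSC1=NCCS1` reaches only the limit of this assay, at > 200000 nM. Compound 3 `CC(C)[C@H](NC(=O)COc1cccc2ccccc12)C(=O)N[C@@H](CC(=O)O)C(=O)CSc1nc(-c2ccccc2)cs1` likewise stops at a limit, > 200000 nM. So compound 2 stands at the upper edge of what this assay can report, with compound 3 beside it at the same edge (the limit of > 200000 nM in this assay, at which 2 of the 3 values shown sit). Replacing the group of compound 1 by the group of compound 2 gave an at least 2.8-fold higher number from compound 1 to compound 2 (0.44 log units; beyond the scatter), and the corresponding change to compound 3 gave an at least 2.8-fold higher number from compound 1 to compound 3 (0.44 log units; beyond the scatter). Between compound 2 and compound 3 the step is a step that the two limits leave unreadable from compound 2 to compound 3.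

Compound 4 `CC(C)[C@H](NC(=O)COc1cccc2ccccc12)C(=O)N[C@@H](CC(=O)O)C(=O)COc1cccc2cccnc12` has not yet been measured. It differs from compound 2 by a group of 11 heavy atoms (9 carbon, 1 nitrogen, 1 oxygen; one six-membered aromatic ring of carbon only, one six-membered aromatic ring with 1 hetero atom) in place of a group of 6 heavy atoms (3 carbon, 1 nitrogen, 2 sulfur; one five-membered non-aromatic ring with 2 hetero atoms), on a saturated chain carbon bound to a carbonyl carbon. Within the data shown here, the most relevant measured step is the one from compound 1 to compound 2, where an oxygen-linked aromatic group on that chain carbon gave a readable number while a sulfur-linked group did not. Compound 4 returns to an oxygen-linked aromatic group, so the expected step is an at least 3.3-fold lower number from compound 2 to compound 4 (0.52 log units; beyond the scatter), downward and beyond the scatter, back toward the region of compound 1. The estimate for compound 4 in this assay is therefore 60000 nM, within a range of 15000 nM to 200000 nM.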

Compound 4, half-maximal inhibitory concentration: > 200000 nM
Compound 4: no number, only a limit; the forecaster's own chance of this, stated with the estimate: 30%; at least 3.3-fold (0.52 log units) between middle value and limit.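

Putting (quinolin-8-yl)oxy on the saturated chain carbon bound to a carbonyl carbon gave an at least 2.8-fold higher number from compound 1 to compound 4 (0.44 log units; beyond the scatter), so an oxygen link to an aromatic group is not enough on its own to keep a readable number. In this assay compound 1 remains the only one of the four with a number, 71000 nM, and the oxygen-linked compound 4 now groups with the sulfur-linked compound 2 and compound 3. The values of compound 2, compound 3 and compound 4 are limits and not numbers, and the steps among them cannot be read, because all three stop at the same edge: the limit of > 200000 nM in this assay, at which 3 of the 4 values shown sit.

From the compounds shown here alone, what remains open is whether the readable number of compound 1 depends on its methoxycarbonyl group or on the 1,2-oxazole ring that carries it. A free carboxylic acid or a plain methyl in place of the methoxycarbonyl group would help separate the two, and any compound with a value clear of the limit would also allow the effect of the oxygen or sulfur link to be read.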